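A few compounds are considered here, and "the series" means these few. Any claim that something is new, unique, unknown or untested is made for them only; others in the source may bear on it.

Compound 1 `Cc1ccsc1CN[C@@H]1C[C@H]2C[C@@H]([C@H]1C)C2(C)C` is the starting point. In an ADME assay on MDCK cells (Canis lupus familiaris) for cytotoxicity, read by microscopy, with a stated time of 48 h (on this read-out higher numbers stand for lower toxicity in this test and lower numbers for higher toxicity in this test), compound 1 gives 10000 nM, the lowest of the three numbers measured here, so it is the most toxic of the three in this test. Compound 2 `CCc1ccsc1CN[C@@H]1C[C@H]2C[C@@H]([C@H]1C)C2(C)C` gives 25000 nM, and compound 3 `C[C@H]1[C@H](NCc2sccc2C2CC2)C[C@H]2C[C@@H]1C2(C)C` gives 25000 nM. The measured steps are a 2.5-fold higher number from compound 1 to compound 2 (0.40 log units; beyond the scatter), a 2.5-fold higher number from compound 1 to compound 3 (0.40 log units; beyond the scatter) and no change at the digits printed from compound 2 to compound 3 (within the scatter); each of them alters only the small group on the aromatic ring, not the ring itself.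

Compound 4 `Cc1csc(CN[C@@H]2C[C@H]3C[C@@H]([C@H]2C)C3(C)C)n1` differs from compound 1 by 4-methyl-1,3-thiazol-2-yl in place of 3-methylthiophen-2-yl on a saturated chain carbon bound to an amine nitrogen. Going by the values given here, no measured step exchanges the ring, so the two ring-substituent steps are only a rough guide to the size of change a ring swap may bring. A step of about a 1.5-fold higher number from compound 1 to compound 4 (0.18 log units; within the scatter) is expected, with wide uncertainty. Compound 4 is estimated at 15000 nM, between 5000 nM and 50000 nM.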

Compound 4, minimum cytotoxic concentration: > 100000 nM
Compound 4: only a limit was reported; the forecaster's own chance of this, stated with the estimate: 15%; at least 6.6-fold (0.82 log units) between middle value and limit.
By their numbers in this assay, from the lowest: compound 1; then compounds 2 and 3 (each within the scatter of the next). At a limit, above all of these: compound 4.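

Earlier steps changed only the small group on the aromatic ring, while exchanging the ring itself gives a larger step in this assay: an at least 10-fold higher number from compound 1 to compound 4 (1.00 log units; beyond the scatter). At this place, on a saturated chain carbon bound to an amine nitrogen, 4-methyl-1,3-thiazol-2-yl in place of 3-methylthiophen-2-yl therefore counts for more than those earlier changes. The reading for compound 4 is a limit and not a number, so the full size of this step stays unknown: the limit of > 100000 nM in this assay, at which 1 of the 4 values shown sits.

Whether the added ring nitrogen alone accounts for the step stays open. Also open, on these data alone, is how a furan or pyridine ring, or the new ring carrying ethyl or cyclopropyl, would read.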